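Ester to acid on the benzyl arm of compound 3

The source may report more compounds than this note shows. Statements on the series, on what has been measured and on what is new or still open speak of the compounds shown alone.

The compounds share one core. Compound 1 `O=c1c2ccccc2sn1CCCCCCN1CCCCC1` carries a chain to a saturated amine and in an assay on HeLa cells for inhibition of Monoglyceride lipase (Rattus norvegicus), read by LC-MS, with a stated time of 10 min (a higher number here means a weaker inhibitor, a lower number a stronger inhibitor), gives 195 nM. Compound 2 `O=c1c2ccccc2sn1NCc1ccccc1` carries a benzylamino arm and in this assay gives 19.5 nM. Compound 3 `COC(=O)c1ccc(CNn2sc3ccccc3c2=O)cc1` adds a methoxycarbonyl to that arm and in this assay gives 93.9 nM, the second highest of the three numbers; the step of a 4.8-fold higher number from compound 2 to compound 3 (0.68 log units; beyond the scatter) shows that this substituent weakens inhibition beyond the scatter. Compound 4 `O=C(O)c1ccc(CNn2sc3ccccc3c2=O)cc1` differs from compound 3 by hydrogen in place of methyl on an oxygen next to a carbonyl group.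

Among the compounds with values here, no measured step concerns the ester oxygen itself; the only relevant step, from compound 2 to compound 3, shows that the substituted position responds to change at all. The direction of the new step is therefore open, and a broad range is needed. Compound 4 is expected to give 160 nM in this assay, within 40 nM to 650 nM. This estimate corresponds to a 1.7-fold higher number from compound 3 to compound 4 (0.23 log units; within the scatter), a modest weakening expected rather than measured.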

Compound 4, half-maximal inhibitory concentration: 278 nM
Compound 4: middle estimate off by 1.7-fold (0.24 log units), on the low side; measured number inside the range.
By their numbers in this assay, from the lowest: compound 2; then compound 3; then compounds 1 and 4 (each within the scatter of the next).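

In this assay the exchange of methyl for hydrogen on the oxygen next to the carbonyl group gives a 3.0-fold higher number from compound 3 to compound 4 (0.47 log units; beyond the scatter) and so weakens inhibition beyond the scatter, which shows that the number depends on the end of the ester as well as on the presence of a substituent on the benzyl arm. Set against the unsubstituted arm, the carboxy group gives a 14-fold higher number from compound 2 to compound 4 (1.15 log units; beyond the scatter) and this is a large step, where the methoxycarbonyl group gave only a 4.8-fold higher number from compound 2 to compound 3 (0.68 log units; beyond the scatter) and a modest one. Nothing shown accounts for the difference between the ester and the acid.

The compounds shown leave open whether a primary amide or a longer ester in the same place would read like the methoxycarbonyl or like the carboxy group. They also leave open whether a hydroxymethyl group, which has no carbonyl, would weaken inhibition at all.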